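A few compounds are considered here, and "the series" means these few. Any claim that something is new, unique, unknown or untested is made for them only; others in the source may bear on it.

Series so far, tested in a functional assay on MCF7 cells (Homo sapiens) for antiproliferative activity, read by MTT assay, with a stated time of 72 h; on this read-out lower numbers stand for stronger inhibition and higher numbers for weaker inhibition:
- Compound 1 `CC(=O)O[C@H]1CC[C@]2(C)[C@H](CC[C@@](C)(O)[C@H]2CC[C@@H]2C(C)=CC[C@@H]3C(C)=CC[C@@H]3C2(C)C)OC1(C)C`: 43500 nM
- Compound 2 `CC1=CC[C@H]2[C@@H]1CC=C(C)[C@@H](CC[C@H]1[C@]3(C)CC[C@H](OC(=O)CCC(=O)O)C(C)(C)O[C@H]3CC[C@@]1(C)O)C2(C)C`: > 50000 nM (a limit of the assay)
- Compound 3 `CC1=CC[C@H]2[C@@H]1CC=C(C)[C@@H](CC[C@H]1[C@]3(C)CC[C@H](OC(=O)c4ccncc4)C(C)(C)O[C@H]3CC[C@@]1(C)O)C2(C)C`: > 50000 nM (a limit of the assay)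

Compound 3 has no numerical value, only the limit > 50000 nM. The same holds for one other compound in the series, and the overall picture is the limit of > 50000 nM in this assay, at which 2 of the 3 values shown sit.

The next compound is compound 4 `CC1=CC[C@H]2[C@@H]1CC=C(C)[C@@H](CC[C@H]1[C@]3(C)CC[C@H](OC(=O)c4ccc(C)cc4)C(C)(C)O[C@H]3CC[C@@]1(C)O)C2(C)C`, with 4-methylphenyl in place of pyridin-4-yl on a carbonyl carbon.

Among the compounds with values here, three measured steps bear on this change, all of them at the same ester carbonyl. The first is an at least 1.1-fold higher number from compound 1 to compound 3 (0.06 log units; that floor lies within the scatter). The second is an at least 1.1-fold higher number from compound 1 to compound 2 (0.06 log units; that floor lies within the scatter). The third is a step that the two limits leave unreadable from compound 2 to compound 3. None of them shows a change beyond the scatter, and none involves a 4-methylphenyl group.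

On this evidence, no step beyond the scatter is expected in this assay, in either direction. The reading for compound 4 is expected to fall near that of compound 1, at 43500 nM. That reading may well end up as a limit too. The expected step is an at least 1.2-fold lower number from compound 3 to compound 4 (0.09 log units; that floor lies within the scatter). Compound 4 is estimated at 40000 nM, with an expected range of 15000 nM to 70000 nM.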

Compound 4, half-maximal inhibitory concentration: > 50000 nM
Compound 4: a limit, no number; the forecaster's own chance of this, stated with the estimate: 45%; at least 1.2-fold (0.09 log units) between middle value and limit.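

In this assay compound 4 gives > 50000 nM, which is a limit of the assay and not a number. Within the data shown here, only one new step can be read, an at least 1.1-fold higher number from compound 1 to compound 4 (0.06 log units; that floor lies within the scatter); the steps to compound 4 from the other two compounds at the limit cannot be read. The result adds a third acyl group on this carbonyl carbon, and the first with an aromatic ring of carbon only, so neither 4-methylphenyl nor pyridin-4-yl gives a numerical reading, and the series now shows this picture: the limit of > 50000 nM in this assay, at which 3 of the 4 values shown sit.

Among these compounds, compound 1 keeps the only numerical value, so any order among the esters of compound 2, compound 3 and compound 4 remains unknown, as does whether any of them differs from compound 1 beyond the scatter. Open too, from the compounds shown here alone, is how this carbonyl position would read with a free hydroxyl in place of the ester, or with an aminoalkyl ester or a longer alkyl chain on the carbonyl carbon.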